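Capping the carboxy group of compound 3

The source may hold more compounds than are shown below. What is called first, only, known or untested is meant among the compounds shown, and "the series" means these compounds.

Values in a functional assay with Oryctolagus cuniculus as the target; a higher number here means a weaker inhibitor, a lower number a stronger inhibitor:
- compound 1 `COc1ccc(-c2nc(/N=C(\N)NC3CCCCC3)sc2-c2ccc(OC)cc2)cc1`: > 1000 nM
- compound 2 `CCOC(=O)/C=C/c1nc(-c2ccc(OC)cc2)c(-c2ccc(OC)cc2)s1`: 20 nM
- compound 3 `COc1ccc(-c2nc(/C=C/C(=O)O)sc2-c2ccc(OC)cc2)cc1`: > 100 nM

Compound 3 gives only a limit, > 100 nM. Compound 1 also gives only a limit, > 1000 nM. The next compound is compound 4 `COc1ccc(-c2nc(/C=C/C(=O)N3CCN(C)CC3)sc2-c2ccc(OC)cc2)cc1`, with 4-methylpiperazin-1-yl in place of hydroxy on a carbonyl carbon. The closest measured step is an at least 5.0-fold higher number from compound 2 to compound 3 (0.69 log units; beyond the scatter), at the same carbonyl group. The step of an at least 50-fold lower number from compound 1 to compound 2 (1.69 log units; beyond the scatter) is a wider exchange and bears less directly, and a step that the two limits leave unreadable from compound 1 to compound 3 adds nothing. With compound 2 at 20 nM as the only capped carbonyl measured, a modest move to a lower number is expected in this assay, though with wide uncertainty. The expected step is an at least 1.6-fold lower number from compound 3 to compound 4 (0.22 log units; that floor lies within the scatter). The estimate for compound 4 is 60 nM, with an expected range of 10 nM to 500 nM.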

Compound 4, half-maximal inhibitory concentration: > 1000 nM
Compound 4: no number, only a limit; the forecaster's own chance of this, stated with the estimate: 35%; at least 16-fold (1.22 log units) between middle value and limit.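

In this assay a capped carbonyl alone does not secure a low number: 4-methylpiperazin-1-yl in place of ethoxy on the carbonyl carbon brings an at least 50-fold higher number from compound 2 to compound 4 (1.69 log units; beyond the scatter) in this one pair. Compound 4 gives > 1000 nM as a limit of the assay, not a number. The step from compound 3 to compound 4 cannot be read, as both values are limits.

On these data alone, it remains open whether this gap belongs to 4-methylpiperazin-1-yl or to amides in general, which a dimethylamide or a morpholine amide would help to separate. Also open, as far as these compounds go, is whether a methyl ester matches the ethyl ester of compound 2.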